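Working notes: the step from compound 2 to compound 3

The compounds below may be only part of what the source reports. "The series", "measured", "known", "first", "only" and "open" are said of these compounds alone.

Measured in a functional assay on ileum (Cavia porcellus) for antagonist activity; a lower number here means a stronger inhibitor, a higher number a weaker inhibitor:
- Compound 1 `COC(=O)c1ccc(OCCCOc2ccc3c(O)c([N+](=O)[O-])c(=O)oc3c2)cc1`: > 10000 nM (a limit)
- Compound 2 `CC(=O)c1ccc(OCCCOc2ccc3c(O)c([N+](=O)[O-])c(=O)oc3c2)cc1O`: 2800 nM

Among the measured compounds shown here, compound 2 holds the only actual number so far. Compound 3 `Cc1ccc(OCCCOc2ccc3c(O)c([N+](=O)[O-])c(=O)oc3c2)c([N+](=O)[O-])c1` has 4-methyl-2-nitrophenyl in place of 4-acetyl-3-hydroxyphenyl on an oxygen on a saturated carbon. For the measured compounds named here, the one measured step at this place, an at least 3.5-fold lower number from compound 1 to compound 2 (0.55 log units; beyond the scatter), brought that same group in, so its removal is expected to give a modestly higher number in this assay. The expected change is a 2.1-fold higher number from compound 2 to compound 3 (0.33 log units; beyond the scatter). For compound 3 the estimate is 6000 nM, with an expected range of 1500 nM to 20000 nM.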

Compound 3, half-maximal inhibitory concentration: > 10000 nM
Compound 3: no number, only a limit (the forecaster's own chance of this, stated with the estimate: 45%); at least 1.6-fold (0.22 log units) between middle value and limit.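

In this assay, the 4-acetyl-3-hydroxyphenyl group on this oxygen does not tolerate exchange for 4-methyl-2-nitrophenyl, a group with the same heavy-atom count: an at least 3.5-fold higher number from compound 2 to compound 3 (0.55 log units; beyond the scatter). Compound 3 gives only a limit, > 10000 nM. The step linking compound 1 and compound 3 cannot be read, and readings at this position rest largely on limits: the limit of > 10000 nM in this assay, at which 2 of the 3 values shown sit.

The exchange alters several parts of the group at once, so the contributions of the acetyl and the hydroxy group stay unseparated. As far as these compounds go, how a phenyl carrying only the acetyl, or one carrying an amine or a carboxylic acid, would read remains open.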